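Quinoline carboxamide series: aryl substituent variation at the quinoline

This account rests on a few compounds, and the source may have more. Where it says the series, first, only, none or still open, it means among the compounds named here.

Measured compounds and values:
- compound 1 `COc1cc2c(Oc3ccc(NC(=O)c4cc(-c5ccc(C)cc5)nc5ccccc45)cc3F)ccnc2cc1OCCCN1CCC(C)CC1`, in a functional assay on MKN-45 cells (Homo sapiens) for cytotoxicity, read by MTT assay, with a stated time of 72 h (a higher number here means a weaker inhibitor, a lower number a stronger inhibitor), 770 nM
- compound 2 `COc1cc2c(Oc3ccc(NC(=O)c4cc(-c5ccc(Cl)c(Cl)c5)nc5ccccc45)cc3F)ccnc2cc1OCCCN1CCCC1`, in this assay 170 nM
- compound 3 `COc1cccc(-c2cc(C(=O)Nc3ccc(Oc4ccnc5cc(OCCCN6CCCC6)c(OC)cc45)c(F)c3)c3ccccc3n2)c1`, in this assay 430 nM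

Compound 3 stands second highest of the three numbers. Its nearest neighbour is compound 1, a higher number within the scatter; its furthest is compound 2, a lower number beyond the scatter.

The step to compound 4 `COc1cc2c(Oc3ccc(NC(=O)c4cc(-c5ccc(C)cc5)nc5ccccc45)cc3F)ccnc2cc1OCCCN1CCCC1` is 4-methylphenyl in place of 3-methoxyphenyl on an aromatic carbon. Among the compounds with values here, no measured pair covers exactly this exchange. Within the data shown here, the one step that touches the same place is a 2.5-fold higher number from compound 2 to compound 3 (0.40 log units; beyond the scatter), a modest change against a different aryl group. The only other bearing comes from compound 1, which carries the same 4-methylphenyl as compound 4 but a different amine on the side chain; compound 1 and compound 3 sit within the scatter of each other. Nothing here points to a step beyond the scatter in either direction in this assay.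

Compound 4 is therefore expected to give 550 nM in this assay, with a range of 250 nM to 1200 nM. The estimated step is a 1.3-fold higher number from compound 3 to compound 4 (0.11 log units; within the scatter), which is taken to be within the scatter.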

Compound 4, half-maximal inhibitory concentration: 300 nM
Beside the measured number, compound 4's estimate is 1.8-fold (0.26 log units) above it; low and high end bracket the measured number.
By their numbers in this assay, from the lowest: compounds 2, 4, 3 and 1 (each within the scatter of the next, the first and the last beyond it).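

Within the data shown here, in (this assay), 4-methylphenyl on the aromatic carbon next to the ring nitrogen falls within the scatter of both other aryl groups (a 1.4-fold lower number from compound 3 to compound 4 (0.16 log units; within the scatter)) (a 1.8-fold higher number from compound 2 to compound 4 (0.25 log units; within the scatter)), so it does not separate them, and the only aryl step beyond the scatter remains the one between 3,4-dichlorophenyl and 3-methoxyphenyl (a 2.5-fold higher number from compound 2 to compound 3 (0.40 log units; beyond the scatter)). Among these compounds, the new compound also gives the first reading at the end of the side chain with the 4-methylphenyl held fixed: pyrrolidin-1-yl in place of 4-methylpiperidin-1-yl gives a modest step beyond the scatter (a 2.6-fold lower number from compound 1 to compound 4 (0.41 log units; beyond the scatter)), so this cell read-out responds to the amine as well as to the aryl group. No supporting measurement bears on the reason for either difference.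

From the compounds shown here alone, whether the amine step carries over to the 3-methoxyphenyl or 3,4-dichlorophenyl compounds remains open, as does the effect of other amines on the same chain, such as morpholin-4-yl or 4-methylpiperazin-1-yl. At the aryl position, the readings leave open how unsubstituted phenyl or a pyridyl ring would compare with the three aryl groups shown.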